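This account rests on a few compounds, and the source may have more. Where it says the series, first, only, none or still open, it means among the compounds named here.

Compound 1 `O=c1c2c(sn1-c1ccc(C(F)(F)F)cc1)CCCC2` gives 74100 nM in a functional assay on the whole organism for inhibition, with Scenedesmus acutus as the target, with a stated time of 20 min (on this read-out lower numbers stand for stronger inhibition and higher numbers for weaker inhibition), the higher of the two numbers seen so far. Compound 2 `O=C1C2=C(CCCC2)S(=O)(=O)N1c1cc(OC2CCCC2)c(Cl)cc1F` gives 1020 nM in this assay, a much lower number, and that gap stands beyond the usual scatter of the measurement. Compound 3 `O=c1c2c(sn1-c1ccc([N+](=O)[O-])cc1)CCCC2` is the untested companion of compound 1, and the change between them is nitro in place of trifluoromethyl on an aromatic carbon. Within the data shown here, no measured pair shows this exchange, so the step is expected to stay within the scatter, with a 1.5-fold lower number from compound 1 to compound 3 (0.17 log units; within the scatter) as the guess. Compound 3 is estimated at 50000 nM, with a range from 15000 nM to 200000 nM.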

Compound 3, half-maximal inhibitory concentration: 23400 nM
Compound 3: the middle estimate sits 2.1-fold (0.33 log units) above what was measured; measured number inside the range.
By their numbers in this assay, from the lowest: compound 2; then compound 3; then compound 1.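

Nitro in place of trifluoromethyl, on an aromatic carbon para to a large group, gives a 3.2-fold lower number from compound 1 to compound 3 (0.50 log units; beyond the scatter) in this assay. Among these compounds, this is the first single-place comparison, and it shows that the group at this position can shift the read-out on the shared core, though only modestly. No measurement here bears on what lies behind the step.

As far as these compounds go, whether an amine or a nitrile at this position would lower the number further remains open. So does whether this exchange would have the same effect on another core.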